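This account rests on a few compounds, and the source may have more. Where it says the series, first, only, none or still open, it means among the compounds named here.

Working notes on the series. Compound 1 `CC(C)c1cc2c(c(O)c1O)[C@]13CO[C@H]2C[C@H]1C(C)(C)C[C@H](O)C3` sets the shared core. In a functional assay on HCT-116 cells (Homo sapiens) for cytotoxicity, read by MTT assay (a higher number here means a weaker inhibitor, a lower number a stronger inhibitor), compound 1 gives only a limit, > 10000 nM, not a number. Compound 2 `CC(C)C1=CC2=C(C(=O)C1=O)[C@]13CO[C@H]2C[C@H]1C(C)(C)C[C@H](O)C3` is a close relative, and in this assay compound 2 gives 7300 nM. Compound 3 `CC(C)C1=C[C@@]23Oc4c(C(C)C)cc5c(c4O[C@]2(C(=O)C1=O)[C@]12CO[C@@H]3C[C@H]1C(C)(C)C[C@H](O)C2)[C@]12CO[C@@H]5C[C@H]1C(C)(C)C[C@H](O)C2` is the larger member of the set. In this assay compound 3 gives a limit, > 10000 nM, and no number. Among the compounds with values here, compound 3 thus sits at the limit of > 10000 nM in this assay, at which 2 of the 3 values shown sit; no step between measured compounds can be drawn from it, and compound 2 supplies the only number in hand.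

Compound 4 `CC(C)C1=C[C@]23Oc4c(C(C)C)cc5c(c4O[C@@]2(C(=O)C1=O)[C@]12CO[C@@H]3C[C@H]1C(C)(C)C[C@H](O)C2)[C@]12CO[C@@H]5C[C@H]1C(C)(C)C[C@H](O)C2` is the next member. Relative to compound 3 the change is the two compounds have the same atoms and bonds and differ only in configuration as drawn: 2 of 10 stereo elements differ; a stereocentre at a saturated ring carbon is drawn S in compound 3 and R in compound 4; a stereocentre at a saturated ring carbon is drawn R in compound 3 and S in compound 4. Within the data shown here, with no measured step for a change of this kind, the expectation for this assay is no step beyond the scatter, in no set direction; the estimated step from compound 3 to compound 4 is a step that the limit leaves unreadable from compound 3 to compound 4. Compound 4 is expected to give about 15000 nM, within 7000 nM to 40000 nM, and most likely to be reported again only as a limit.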

Compound 4, half-maximal inhibitory concentration: 6300 nM
Compound 4: middle estimate off by 2.4-fold (0.38 log units), on the high side; the measured number lies below the stated range.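

In this assay the series now has its first readable step, and it comes from configuration alone, with nothing leaving or entering: an at least 1.5-fold lower number from compound 3 to compound 4 (0.20 log units; that floor lies within the scatter). Compound 3 gives only a limit, > 10000 nM, so the printed step is a floor that lies within the scatter and does not establish a real separation of the pair. Any true difference between the two compounds could lie only in the two stereocentres at saturated ring carbons: the fact that compounds 3 and 4 differ only in the configuration as drawn

From the compounds shown here alone, the true size of the step remains open, as does whether either stereocentre alone would carry it. Also open, going by these compounds, is how the pair would read in this assay if an amine or a carboxylic acid took the place of the hydroxyl group.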